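The source may report more compounds than this note shows. Statements on the series, on what has been measured and on what is new or still open speak of the compounds shown alone.

Measured compounds:
compound 1, `Cc1cnc(C[S+]([O-])C(c2ccccc2)c2ccccc2)nc1`: 156000 nM
compound 2, `[O-][S+](Cc1cccs1)C(c1ccc(F)cc1)c1ccc(F)cc1`: 4000 nM

Both numbers come from an assay on HEK293 cells for inhibition of sodium-dependent dopamine transporter (Homo sapiens), read by scintillation counting, with stated times of 5 min and 1 min; a higher number here means a weaker inhibitor, a lower number a stronger inhibitor. Of the two, compound 1 has the higher number; compound 2 lies well below it, and that gap is wider than the usual scatter. Going by the values given here, compound 1 and compound 2 differ in more than one place, so no single step connects them.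

Compound 3, `[O-][S+](Cc1ccsc1)C(c1ccccc1)c1ccccc1`, has not yet been measured. It comes from compound 1 by one change: thiophen-3-yl in place of 5-methylpyrimidin-2-yl on a saturated chain carbon bound to a sulfur. The rest of the core of compound 1 stays as it is.

Among the compounds with values here, no step between two measured compounds matches this change, so the expectation rests on the two values alone. In this assay compound 1 gives 156000 nM, while compound 2, whose group on that carbon is closely related to the thiophen-3-yl that enters, gives 4000 nM. That comparison suggests that bringing a thiophen-3-yl into compound 1 is likely to lower the number. The step from compound 1 to compound 3 is therefore expected to be large and downward, a 16-fold lower number from compound 1 to compound 3 (1.19 log units; beyond the scatter), beyond the scatter. For compound 3 the estimate is 10000 nM, with a range from 2500 nM to 40000 nM.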

Compound 3, half-maximal inhibitory concentration: 3000 nM
Compound 3: the middle estimate sits 3.3-fold (0.52 log units) above what was measured, within the range that was stated.
By their numbers in this assay, from the lowest: compounds 3 and 2 (each within the scatter of the next); then compound 1.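

Replacing 5-methylpyrimidin-2-yl with thiophen-3-yl on a saturated chain carbon bound to a sulfur gives, in this assay, a 52-fold lower number from compound 1 to compound 3 (1.72 log units; beyond the scatter). Going by these compounds alone, this is the first reading of a single change, and it shows that the group at this place can, with the rest of the core of compound 1 unchanged, move the number far beyond the usual scatter. The change alters several things at once, replacing a six-membered aromatic ring with 2 hetero atoms and 2 hydrogen-bond acceptors by a five-membered aromatic ring with 1 hetero atom and 1 hydrogen-bond acceptor, and no measurement here separates these differences or explains the drop.

The compounds shown leave open whether the low number is particular to thiophen-3-yl or would also come with a plain phenyl ring, a saturated cyclohexyl ring or an amine at this place. They also leave open whether the same swap would produce a step of similar size on a core carrying other groups, such as the fluorine-bearing rings of compound 2.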